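A few compounds are considered here, and "the series" means these few. Any claim that something is new, unique, unknown or untested is made for them only; others in the source may bear on it.

Compound 1 `COc1ccc(/C=C/C(=O)c2ccccc2)cc1S(=O)(=O)N(C)C` and compound 2 `COc1ccc(/C=C/C(=O)c2ccccc2)cc1S(=O)(=O)Nc1ccc(Cl)cc1` share one core and differ only at the sulfonyl sulfur. In an ADME assay on cells (Macrophage, Mus musculus) for cytotoxicity, read by MTT assay, with a stated time of 72 h (on this read-out lower numbers stand for higher toxicity in this test and higher numbers for lower toxicity in this test), compound 1 gives 57800 nM, and compound 2 gives 57800 nM, so compound 1 stands level with compound 2 on this read-out. The step of no change at the digits printed from compound 1 to compound 2 (within the scatter) places (4-chlorophenyl)amino in place of dimethylamino on the sulfonyl sulfur without moving the read-out beyond the scatter.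

Compound 3 `COc1ccc(NS(=O)(=O)c2cc(/C=C/C(=O)c3ccccc3)ccc2OC)cc1` is not yet measured. Its change from compound 1 is (4-methoxyphenyl)amino in place of dimethylamino on a sulfonyl sulfur. Within the data shown here, the one measured step that bears on it, no change at the digits printed from compound 1 to compound 2 (within the scatter), swapped the same dimethylamino for a different (4-chlorophenyl)amino group at the same sulfonyl sulfur and gave no change. For compound 3 the step of no change at the digits printed from compound 1 to compound 3 (within the scatter) is therefore expected to stay within the scatter. Compound 3 is estimated at 57800 nM, with a range from 25000 nM to 130000 nM.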

Compound 3, half-maximal cytotoxic concentration: 57800 nM
Compound 3: middle estimate and measured number agree at the digits printed; the measured number falls inside the stated range.
By their numbers in this assay, from the lowest: compounds 1, 2 and 3 (each within the scatter of the next).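

In this assay the swap of dimethylamino for (4-methoxyphenyl)amino on the sulfonyl sulfur gives no change at the digits printed from compound 1 to compound 3 (within the scatter), so the level held by compound 2 is not peculiar to its (4-chlorophenyl)amino group. The pair of aryl amino groups adds a direct reading on the substituent of that aromatic ring: methoxy in place of chloro on an aromatic carbon gives no change at the digits printed from compound 2 to compound 3 (within the scatter), so this exchange also leaves the read-out within the scatter. Nothing at hand accounts for this sameness.

Open, on these data alone, is whether a group of another kind on the sulfonyl sulfur, such as a carboxylic acid or a longer alkyl chain, would leave the read-out at this level. Also open, as far as these compounds go, is whether the level in this assay would hold with a hydroxyl in place of the methoxy on the shared core.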